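Lengthening the propyl chain on a sulfonylurea: compound 3

The source may report more compounds than this note shows. Statements on the series, on what has been measured and on what is new or still open speak of the compounds shown alone.

Measured compounds:
compound 1, `CCCCNC(=O)NS(=O)(=O)c1ccc(-n2nc(-c3ccc(OC)cc3)ccc2=O)cc1`, 25.6%
compound 2, `CCCNC(=O)NS(=O)(=O)c1ccc(-n2nc(-c3ccc(C)cc3)ccc2=O)cc1`, 109%

Of the compounds shown here, two have been measured in a functional assay on the whole organism (blood, strain Wistar albino) for inhibition, with Rattus norvegicus as the target, read by colorimetric assay, with stated times of 15 min and 90 min, at a dose of 20 mg/kg by the oral route; a lower number here means less inhibition, a higher number more inhibition at the dose given (going by the name of the read-out). Compound 1 gives 25.6%. Compound 2 gives 109% and so stands highest of the two numbers, a gap to compound 1 that lies beyond the scatter. Compound 1 and compound 2 differ in two places at once, so their two values alone cannot be split between the chain and the methoxy group.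

Compound 3, `CCCCNC(=O)NS(=O)(=O)c1ccc(-n2nc(-c3ccc(C)cc3)ccc2=O)cc1`, carries the change (methyl in place of hydrogen on a saturated chain carbon, three bonds along the chain from an amide-type nitrogen), which read one bond further out is propyl to butyl. Among the compounds with values here, no single-place step between measured compounds is known, so the size of the step from compound 2 cannot be read from data; a modest fall is expected, though it may also stay within the scatter. Compound 3 is therefore estimated at 80%, within 35% to 110%, an expected step of a number 29 percentage points lower from compound 2 to compound 3 (beyond the scatter).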

Compound 3, a percentage reported as inhibition, in the whole organism at one dose (the size of the read-out at that dose, not a potency): 109%
Beside the measured number, compound 3's estimate is 29 percentage points below it, within the range that was stated.
By their numbers in this assay, from the lowest: compound 1; then compounds 2 and 3 (each within the scatter of the next).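

In this assay, the change of methyl in place of hydrogen on a saturated chain carbon, which reads as propyl to butyl, gives no change at the digits printed from compound 2 to compound 3 (within the scatter), so at this dose the chain position accepts the longer butyl without a readable shift. With the butyl chain held constant, methyl in place of methoxy on an aromatic carbon gives a number 83.4 percentage points higher from compound 1 to compound 3 (beyond the scatter), which places a large difference at that aromatic position, a separation that the two earlier compounds, differing in two places at once, could not provide. Nothing measured here explains either result.

As far as these compounds go, whether a pentyl chain or a cyclohexyl group in place of butyl would keep the read-out remains open. So does how a chlorine or a hydrogen in place of the aromatic methyl would compare with methyl and methoxy.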